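Chain extension at the limit: compound 3 to compound 4

The compounds below may be only part of what the source reports. "The series", "measured", "known", "first", "only" and "open" are said of these compounds alone.

Measured in a functional assay on HCT-116 cells (Homo sapiens) for antiproliferative activity, read by MTT assay, with a stated time of 48 h (on this read-out lower numbers stand for stronger inhibition and higher numbers for weaker inhibition), each value a limit:
- compound 1 `CC(CCO)n1cnc2c(Cl)ncnc21`: > 50000 nM
- compound 2 `CCCCCC(CCO)n1cnc2c(Cl)ncnc21`: > 50000 nM
- compound 3 `C=C(CO)C(CCCCC)n1cnc2c(Cl)ncnc21`: > 50000 nM

Compound 3 is known only as a limit: the limit of > 50000 nM in this assay, at which 3 of the 3 values shown sit.

Unmeasured compound 4 `C=C(CO)C(CCCCCC)n1cnc2c(Cl)ncnc21` differs from it by methyl in place of hydrogen on a saturated chain carbon, six bonds along the chain from an aromatic nitrogen and a double-bonded chain carbon.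

Going by the values given here, two measured steps bear on this change, a step that the two limits leave unreadable from compound 1 to compound 2 and a step that the two limits leave unreadable from compound 2 to compound 3. The first is the closer, being also a chain addition, but neither has a readable size, so neither gives a direction. No clear change is therefore expected in this assay, and a further limit is the likeliest report.

The expected step is a number no higher from compound 3 to compound 4 (the limit leaves the size open).

For compound 4 the estimated value is 50000 nM, with an expected range of 20000 nM to 100000 nM.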

Compound 4, half-maximal inhibitory concentration: 30200 nM
Compound 4: the middle estimate sits 1.7-fold (0.22 log units) above what was measured, and the stated range covers the measured number.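

Compound 4 is the only compound shown with a number rather than a limit in this assay, so methyl in place of hydrogen at this chain position gives the one step of the series with a readable floor. Going by these compounds alone, that step is an at least 1.6-fold lower number from compound 3 to compound 4 (0.21 log units; that floor lies within the scatter), while the earlier steps cannot be read. The remaining compounds stay at a limit: the limit of > 50000 nM in this assay, at which 3 of the 4 values shown sit.

On these data alone, the true size of the step remains open, since the reading for compound 3 is only a limit. Also open, as far as these compounds go, is whether a longer chain at this position, or an amine in place of the hydroxyl of the 1-(hydroxymethyl)ethenyl group, would give a lower number.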